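A few compounds are considered here, and "the series" means these few. Any claim that something is new, unique, unknown or untested is made for them only; others in the source may bear on it.

In a functional assay on LOX IMVI cells (Homo sapiens) for cytotoxicity, read by MTT assay, with a stated time of 24 h (a lower number here means a stronger inhibitor, a higher number a weaker inhibitor), the series stands so far as follows.

- compound 1 (`COc1cc(-c2nc(-c3ccccc3)[nH]c2-c2ccnc(NCCCNS(=O)(=O)c3ccc(Cl)cc3)n2)ccc1F`) gives 83100 nM
- compound 2 (`COc1cc(-c2nc(-c3ccccc3)[nH]c2-c2ccnc(NCCCNS(=O)(=O)c3ccc(Cl)cc3)n2)ccc1Cl`) gives 60900 nM
- compound 3 (`O=S(=O)(NCCCNc1nccc(-c2[nH]c(-c3ccccc3)nc2-c2ccc(Cl)c(O)c2)n1)c1ccc(Cl)cc1`) gives 61300 nM

The three values form one group, with a 1.4-fold lower number from compound 1 to compound 2 (0.13 log units; within the scatter), a 1.4-fold lower number from compound 1 to compound 3 (0.13 log units; within the scatter) and a 1.0-fold higher number from compound 2 to compound 3 (0.00 log units; within the scatter) as the steps among them. Compound 3 therefore has no separate place within that group.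

Compound 4 (`COc1ccc(S(=O)(=O)NCCCNc2nccc(-c3[nH]c(-c4ccccc4)nc3-c3ccc(Cl)c(O)c3)n2)cc1`) differs from compound 3 by methoxy in place of chloro on an aromatic carbon, para to a large group (methoxy in place of chloro on an aromatic carbon). The sulfonyl group thus changes from (4-chlorophenyl)sulfonyl to (4-methoxyphenyl)sulfonyl.

Among the compounds with values here, no measured step covers this change, as compound 1, compound 2 and compound 3 all carry the 4-chlorophenyl group. The evidence is indirect and consists only of the three steps above, which were all made elsewhere in the molecule and all stayed within the scatter. On that thin basis, no shift beyond the scatter is expected in this assay, and no direction is firmly expected.

The expected step is a 1.1-fold higher number from compound 3 to compound 4 (0.03 log units; within the scatter), which would leave the series in one group.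

For compound 4 the estimated value is 65000 nM, with an expected range from 30000 nM to 130000 nM.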

Compound 4, half-maximal inhibitory concentration: 36800 nM
Compound 4: the middle estimate sits 1.8-fold (0.25 log units) above what was measured, within the range that was stated.
By their numbers in this assay, from the lowest: compounds 4, 2, 3 and 1 (each within the scatter of the next, the first and the last beyond it).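

Working from the shared core of compound 3, this assay gives the first reading at the sulfonyl aryl group, where 4-chlorophenyl to 4-methoxyphenyl gives a 1.7-fold lower number from compound 3 to compound 4 (0.22 log units; within the scatter) and leaves both compounds in one group. The earlier compounds shown here all carry the 4-chlorophenyl group and varied only the other aryl group, so they said nothing about this place; methoxy in place of chloro on this aromatic carbon, para to a large group, now shows no shift beyond the scatter, although one more heavy atom and one more hydrogen-bond acceptor enter. Within the data shown here, no measured property accompanies this change, so the data offer no account of the step, whose direction also cannot be read from a change this small.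

A single step cannot show whether the same change would read alike on compound 1 or compound 2, which differ from compound 3 in the other aryl group. Also open, going by these compounds, is whether an amine or a carboxylic acid at this place on the ring, or a longer alkoxy chain in place of methoxy, would stay in the same group.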